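Replacing a fluorinated side chain with phenylsulfamoyl

A few compounds are considered here, and "the series" means these few. Any claim that something is new, unique, unknown or untested is made for them only; others in the source may bear on it.

The compounds share one core, carrying a para substituent on the phenyl ring that was varied. Compound 1 `CC#C[C@H]1CN(S(=O)(=O)c2ccc(N)nc2)CCN1c1ccc(C(O)(COC)C(F)(F)F)cc1` bears a group of 9 heavy atoms there; in an ADME assay (liver) for metabolic stability, with Liver microsome (Rattus norvegicus) as the target, using microsomes and NADPH, with a stated time of 30 min (on this read-out higher numbers stand for fast clearance and lower numbers for slow clearance), compound 1 gives 93 mL.min-1.g-1. This is the highest of the two plain numbers shown, with compound 3 `CC#C[C@H]1CN(S(=O)(=O)c2ccc(N)nc2)CCN1c1ccc([S+](C)[O-])cc1` giving 17 mL.min-1.g-1 in this assay, a step of a 5.5-fold lower number from compound 1 to compound 3 (0.74 log units; beyond the scatter). Compound 2 `CC#C[C@H]1CN(S(=O)(=O)c2ccc(N)nc2)CCN1c1ccccc1` gives only a limit of the assay in this assay, > 399 mL.min-1.g-1, so the limit of > 399 mL.min-1.g-1 in this assay, at which 1 of the 3 values shown sits, is all that can be said of it. The step from compound 2 to compound 3 was an at least 23-fold lower number from compound 2 to compound 3 (1.37 log units; beyond the scatter).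

Compound 4 `CC#C[C@H]1CN(S(=O)(=O)c2ccc(N)nc2)CCN1c1ccc(S(=O)(=O)Nc2ccccc2)cc1` carries a group of 10 heavy atoms (6 carbon, 1 nitrogen, 2 oxygen, 1 sulfur; one six-membered aromatic ring of carbon only) in place of a group of 9 heavy atoms (4 carbon, 2 oxygen, 3 fluorine; no ring), on an aromatic carbon. Within the data shown here, the steps that bear on it are those from compound 1, namely an at least 4.2-fold higher number from compound 1 to compound 2 (0.63 log units; beyond the scatter) toward faster clearance and a 5.5-fold lower number from compound 1 to compound 3 (0.74 log units; beyond the scatter) toward slower clearance, both starting from the same group that leaves here. The entering group is larger than either replacement seen so far, so the direction is uncertain; a step no larger than modest is expected, probably toward slower clearance, a 1.6-fold lower number from compound 1 to compound 4 (0.19 log units; within the scatter). Compound 4 is therefore estimated to give 60 mL.min-1.g-1 in this assay, within a range from 20 mL.min-1.g-1 to 200 mL.min-1.g-1.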

Compound 4, intrinsic clearance in microsomes: > 399 mL.min-1.g-1
Compound 4: no number, only a limit; the forecaster's own chance of this, stated with the estimate: 5%; middle value at least 6.6-fold (0.82 log units) away from the limit.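

Among these compounds, compound 4 is the first compound here that carries a group at this place on the phenyl ring and still moves toward faster clearance in this assay: the step is an at least 4.2-fold higher number from compound 1 to compound 4 (0.63 log units; beyond the scatter), and against the other sulfur-bearing group it is an at least 23-fold higher number from compound 3 to compound 4 (1.37 log units; beyond the scatter). A sulfur atom in the group at this place therefore does not by itself go with slow clearance. The reading for compound 4 is a limit of the assay, as is the reading for compound 2, which has only hydrogen here, so the step between them cannot be read and phenylsulfamoyl can only be said to sit with hydrogen at the top of the range: the limit of > 399 mL.min-1.g-1 in this assay, at which 2 of the 4 values shown sit.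

The compounds shown leave open whether the high reading follows the phenyl ring of phenylsulfamoyl or the sulfonyl link that holds it. As far as these compounds go, an unsubstituted sulfamoyl group or a methylsulfonyl group at this place would separate the two, and how far compound 4 lies beyond the limit of the assay remains unknown.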